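A few compounds are considered here, and "the series" means these few. Any claim that something is new, unique, unknown or untested is made for them only; others in the source may bear on it.

Compound 1 `O=C(/C=C/CNCCOc1ccc(Oc2c(-c3ccc(F)cc3)sc3cc(O)ccc23)cc1)N1CCCC1`, compound 2 `C=CC(=O)NCCOc1ccc(Oc2c(-c3ccc(F)cc3)sc3cc(O)ccc23)cc1` and compound 3 `C=C(C)C(=O)NCCOc1ccc(Oc2c(-c3ccc(F)cc3)sc3cc(O)ccc23)cc1` share one core and differ only in the group carried on an amine nitrogen. In a functional assay on MDA-MB-231 cells (Homo sapiens) for antiproliferative activity, read by CCK-8 assay, with a stated time of 48 h (on this read-out higher numbers stand for weaker inhibition and lower numbers for stronger inhibition), compound 1 gives only a limit, > 50000 nM. Compound 2 likewise gives only a limit in this assay, > 50000 nM. Compound 3 too sits at a limit in this assay, > 50000 nM. The steps a step that the two limits leave unreadable from compound 1 to compound 2, a step that the two limits leave unreadable from compound 1 to compound 3 and a step that the two limits leave unreadable from compound 2 to compound 3 therefore cannot be sized, as the limit of > 50000 nM in this assay, at which 3 of the 3 values shown sit, shows. Compound 4 `CNC(=O)/C=C/CNCCOc1ccc(Oc2c(-c3ccc(F)cc3)sc3cc(O)ccc23)cc1` has not yet been measured; it differs from compound 3 by 3-(methylcarbamoyl)prop-2-en-1-yl in place of (1-methylethenyl)carbonyl on an amine nitrogen. Among the compounds with values here, none of the measured steps bears on this change in a readable way, since every earlier value is a limit, so neither direction nor size of any effect can be drawn from them. Compound 4 is therefore expected to show an estimated step that the limit leaves unreadable from compound 3 to compound 4, most likely being reported once more as a limit. The estimate for compound 4 in this assay is 60000 nM, with an expected range from 20000 nM to 200000 nM.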

Compound 4, half-maximal inhibitory concentration: > 50000 nM
Compound 4 ended at the assay's limit; the forecaster's own chance of this, stated with the estimate: 80%; the middle value is on the limit's open side.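

Within the data shown here, compound 4 also gives only a limit in this assay, so no step among compound 1, compound 2, compound 3 and compound 4 can be read, as all four sit at one limit: the limit of > 50000 nM in this assay, at which 4 of the 4 values shown sit. The compounds shown leave open whether any of these groups on the amine nitrogen changes antiproliferative activity, and in which direction.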